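This account rests on a few compounds, and the source may have more. Where it says the series, first, only, none or still open, it means among the compounds named here.

Compound 1 `C[C@@H](O[C@H]1CN2C(=O)C=C(c3ccc(F)cc3)CC2[C@@H]1c1ccc(F)cc1)c1cc(C(F)(F)F)cc(C(F)(F)F)c1` gives 2 nM in an assay on CHO cells for displacement of a labelled ligand from Substance-P receptor (Homo sapiens) (a higher number here means a weaker inhibitor, a lower number a stronger inhibitor), and compound 2 `C[C@@H](O[C@H]1CN2C(=O)C=C(c3cnn(Cc4ccccc4)c3)CC2[C@@H]1c1ccc(F)cc1)c1cc(C(F)(F)F)cc(C(F)(F)F)c1` gives 1.9 nM; the two numbers lie within the scatter of each other, so neither can be called the stronger. Going by the values given here, the one measured step, a 1.1-fold lower number from compound 1 to compound 2 (0.02 log units; within the scatter), shows that swapping one aromatic group for another at this position changed little. Compound 3 `C[C@@H](O[C@H]1CN2C(=O)C=C(C3=CCOCC3)CC2[C@@H]1c1ccc(F)cc1)c1cc(C(F)(F)F)cc(C(F)(F)F)c1` differs from compound 2 by a group of 6 heavy atoms (5 carbon, 1 oxygen; one six-membered non-aromatic ring with 1 hetero atom) in place of a group of 12 heavy atoms (10 carbon, 2 nitrogen; one five-membered aromatic ring with 2 hetero atoms, one six-membered aromatic ring of carbon only), on a double-bonded ring carbon. Among the compounds with values here, no measured step covers a non-aromatic group here, so the expectation rests only on that tolerance; compound 3 is estimated at 5 nM, between 1.5 nM and 20 nM, a change of a 2.6-fold higher number from compound 2 to compound 3 (0.42 log units; beyond the scatter) expected.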

Compound 3, half-maximal inhibitory concentration: 0.18 nM
Compound 3: the middle estimate sits 28-fold (1.44 log units) above what was measured; measured number outside the range, below it.
By their numbers in this assay, from the lowest: compound 3; then compounds 2 and 1 (each within the scatter of the next).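

Replacing either aromatic group with the non-aromatic six-membered ring, which holds one oxygen and one double bond, brings an 11-fold lower number from compound 2 to compound 3 (1.02 log units; beyond the scatter) and an 11-fold lower number from compound 1 to compound 3 (1.05 log units; beyond the scatter) at this double-bonded ring carbon. So this position does more than accept different groups: the group placed here can clearly strengthen inhibition, and an aromatic ring is not needed for that. Nothing measured here explains the gain. Still open, from the compounds shown here alone, is whether the ring oxygen or the double bond matters, as a saturated tetrahydropyran ring or a piperidine ring, an amine, would test.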